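Removing One Methyl from a Methoxymethoxy Compound

The source may report more compounds than this note shows. Statements on the series, on what has been measured and on what is new or still open speak of the compounds shown alone.

In a functional assay on MDA-MB-231 cells (Homo sapiens) for antiproliferative activity, read by MTT assay (on this read-out higher numbers stand for weaker inhibition and lower numbers for stronger inhibition), compound 1 (`CC/C=C\C/C=C\C/C=C\CCCCCCCc1cc(=O)c2c(O)c(C)c(O)cc2o1`) gives 6790 nM, and compound 2 (`CC/C=C\C/C=C\C/C=C\CCCCCCCc1cc(=O)c2c(O)c(C)c(OCOC)c(C)c2o1`) gives 16100 nM. Compound 2 therefore holds the higher of the two numbers, with compound 1 lower by a margin beyond the scatter. Compound 3 (`CC/C=C\C/C=C\C/C=C\CCCCCCCc1cc(=O)c2c(O)c(C)c(OCOC)cc2o1`) keeps the methoxymethoxy group of compound 2 but carries hydrogen in place of methyl on an aromatic carbon. Among the compounds with values here, no measured pair of compounds differs in only one place, so the data do not show the size of this change on its own. Within the data shown here, the only guide is the lower number of compound 1 at 6790 nM, so a small move towards lower numbers in this assay, possibly no larger than the scatter, is expected. The estimated change is a 1.5-fold lower number from compound 2 to compound 3 (0.17 log units; within the scatter). For compound 3 the expected value is 11000 nM, with an estimated range from 4500 nM to 27000 nM.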

Compound 3, half-maximal inhibitory concentration: 6790 nM
Compound 3: middle estimate off by 1.6-fold (0.21 log units), on the high side, and the stated range covers the measured number.
By their numbers in this assay, from the lowest: compounds 1 and 3 (each within the scatter of the next); then compound 2.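

In this assay, within the data shown here, hydrogen in place of methyl on this aromatic carbon gives a 2.4-fold lower number from compound 2 to compound 3 (0.37 log units; beyond the scatter) and so puts a size on this single methyl for the first time, a modest one beyond the scatter. Methoxymethyl in place of hydrogen on the oxygen gives no change at the digits printed from compound 1 to compound 3 (within the scatter) and so leaves no readable mark while the aromatic carbon carries hydrogen. Among these compounds, of these two steps, only the one at the methyl lies beyond the scatter.

On these data alone, it remains open whether an ethyl group, a methoxy group or a chlorine atom on this aromatic carbon would move the number in the same direction as the methyl. As far as these compounds go, it is also open whether the methyl step keeps its size when the oxygen carries hydrogen instead of methoxymethyl. Nothing shown here gives a measured reason for either step.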